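From 2,6-difluorophenyl to tert-butoxy on a carbonyl carbon

The compounds below may be only part of what the source reports. "The series", "measured", "known", "first", "only" and "open" are said of these compounds alone.

In a physicochemical assay for lipophilicity, at pH 7.4 (on this read-out lower numbers stand for lower lipophilicity and higher numbers for higher lipophilicity), compound 1 (`Cc1cc(C(=O)Nc2ccccc2)nn1Cc1cc(Cl)ccc1OCc1ccccc1`) gives > 3.7 as a limit of the assay and not a number. Compound 2 (`Cc1cc(NC(=O)C(C)C)nn1Cc1cc(Cl)ccc1OCc1ccccc1`) gives > 3.7 as a limit too. Compound 3 (`Cc1cc(NC(=O)c2c(F)cccc2F)nn1Cc1cc(Cl)ccc1OCc1ccccc1`) gives > 3.7 as a limit as well, so its place on the scale is known only as that limit.

Compound 4 (`Cc1cc(NC(=O)OC(C)(C)C)nn1Cc1cc(Cl)ccc1OCc1ccccc1`) has not yet been measured. It carries tert-butoxy in place of the 2,6-difluorophenyl of compound 3 on a carbonyl carbon (tert-butoxy in place of 2,6-difluorophenyl on a carbonyl carbon). The measured change nearest to this one swaps isopropyl and 2,6-difluorophenyl on a carbonyl carbon. It is a step that the two limits leave unreadable from compound 2 to compound 3 and so offers no size to carry over. The two remaining steps, a step that the two limits leave unreadable from compound 1 to compound 2 and a step that the two limits leave unreadable from compound 1 to compound 3 in turn, offer none either.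

Every measured compound sits at the same limit (the limit of > 3.7 in this assay, at which 3 of the 3 values shown sit) and compound 4 is expected to lie in that region too. The expected outcome is a step that the limit leaves unreadable from compound 3 to compound 4 in this assay with no direction that these data could support. For compound 4 the estimated value is 3.9 with an expected range from 3.4 to 4.4. There is a good chance that compound 4 will yield only a limit.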

Compound 4, distribution coefficient: > 3.7
Compound 4 gave a limit, no number; the forecaster's own chance of this, stated with the estimate: 75%; the middle value lies beyond the limit too.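

Compound 4 gives only a limit in this assay, so the steps to it from compound 1, compound 2 and compound 3 cannot be read. The values shown share a single limit: the limit of > 3.7 in this assay, at which 4 of the 4 values shown sit. The compounds shown leave open how these four compounds rank against one another, and how large any of the changes between them is.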